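The compounds below may be only part of what the source reports. "The series", "measured", "known", "first", "only" and "open" are said of these compounds alone.

Values in a toxicity assay on cells (Macrophage, Mus musculus, strain BALB/c) for cytotoxicity, read by MTT assay (on this read-out lower numbers stand for stronger inhibition and higher numbers for weaker inhibition), follow.

- compound 1 `C=CCOc1cc(OC)c(C(=O)/C=C/c2ccc(F)cc2)c(OCC=C)c1` gives 13800 nM
- compound 2 `COc1cccc(/C=C/C(=O)c2c(O)cc(O)cc2OC)c1` gives 17600 nM

Compound 1 has only compound 2 as a neighbour on this scale, and the two values lie within the scatter of each other, so neither can be ranked ahead. Going by the values given here, the two compounds do not form a single-place pair, so no measured step exists for this series.

Compound 3 `C=CCOc1cc(OC)c(C(=O)/C=C/c2ccc([N+](=O)[O-])cc2)c(OCC=C)c1` is still unmeasured. It departs from compound 1 at one place only, (nitro in place of fluoro on an aromatic carbon). This is nitro in place of fluoro on an aromatic carbon, para to a large group, or 4-fluorophenyl to 4-nitrophenyl. The rest of the core of compound 1 stays the same.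

Among the compounds with values here, with no measured precedent for this exchange, the only anchor is compound 1 itself at 13800 nM, and the range must stay wide. A small move towards a lower number is expected, quite possibly no larger than the scatter. The expected step is a 1.3-fold lower number from compound 1 to compound 3 (0.10 log units; within the scatter). For compound 3 the estimated value is 11000 nM, with an expected range from 4000 nM to 30000 nM.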

Compound 3, half-maximal inhibitory concentration: 13200 nM
The estimate for compound 3 lay 1.2-fold (0.08 log units) below the measured number; the range from low to high includes it.
By their numbers in this assay, from the lowest: compounds 3, 1 and 2 (each within the scatter of the next).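

In this assay, going by these compounds alone, nitro in place of fluoro on an aromatic carbon, para to a large group, gives the only measured step (a 1.0-fold lower number from compound 1 to compound 3 (0.02 log units; within the scatter)), and that step lies within the scatter. This position therefore accepts nitro as well as fluoro without the read-out telling them apart: compound 1 gives 13800 nM and compound 3 gives 13200 nM, although the entering group has 3 heavy atoms and 2 hydrogen-bond acceptors where the leaving fluoro has 1 heavy atom and 0 hydrogen-bond acceptors. No supporting measurement bears on this result, so it stands as an observation for this one pair only.

From the compounds shown here alone, whether the same flat read-out holds at this place for an amine, which can add a hydrogen-bond donor, or for a carboxylic acid remains open. Also open, going by these compounds, is how this assay responds to changes elsewhere on the core of compound 1, such as a longer chain in place of either ether chain, since this single step speaks only to the 4-fluorophenyl to 4-nitrophenyl exchange.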